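This account rests on a few compounds, and the source may have more. Where it says the series, first, only, none or still open, it means among the compounds named here.

Among the compounds with values here, compound 2, `CCOC(=O)C1=C(Nc2ccccc2)S/C(=C\c2ccc(O)c(O)c2)C1=O`, stands highest of the two numbers known in a functional assay on MCF7 cells (Homo sapiens) for inhibition, read by MTT assay, with a stated time of 72 h, tested at 10 uM; on this read-out lower numbers stand for less inhibition and higher numbers for more inhibition at the one concentration tested (going by the name of the read-out): compound 2 gives 38.1%, and its nearest neighbour is compound 1, `CCOC(=O)C1=C(Nc2ccccc2)S/C(=C\c2ccccc2)C1=O`, which in this assay gives 23.6%. Within the data shown here, the one step that separates them, a number 14.5 percentage points higher from compound 1 to compound 2 (beyond the scatter), came from putting 3,4-dihydroxyphenyl in place of phenyl on a double-bonded chain carbon bound to a double-bonded ring carbon.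

Compound 3, `CCOC(=O)C1=C(Nc2ccccc2)S/C(=C\c2ccc([N+](=O)[O-])c(O)c2)C1=O`, is the next compound in line. It differs from compound 2 in a single place: nitro in place of hydroxy on an aromatic carbon.

Among the measured compounds shown here, the only measured step that bears on this change is the one from compound 1 to compound 2, where the pair of hydroxy groups arrived together and brought a modest rise. For the measured compounds named here, no measured pair shows what happens when one hydroxy goes and a nitro takes its place, so that step gives direction only loosely. Compound 3 is therefore expected to land near compound 2, with a step of a number 4.1 percentage points lower from compound 2 to compound 3 (within the scatter) in this assay that may well stay within the scatter. The estimate for compound 3 is 34%, with a range from 14% to 58%.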

Compound 3, a percentage reported as inhibition, at one concentration (the size of the read-out at that concentration, not a potency): 41.5%
For compound 3 the middle estimate is 7.5 percentage points below the measured one; the measured number falls inside the stated range.
By their numbers in this assay, from the lowest: compound 1; then compounds 2 and 3 (each within the scatter of the next).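

In this assay, the step of a number 3.4 percentage points higher from compound 2 to compound 3 (within the scatter) shows that this aromatic carbon, ortho to a hydroxy group and para to a large group, takes nitro in place of hydroxy without a difference that the read-out can separate from scatter. The earlier step, a number 14.5 percentage points higher from compound 1 to compound 2 (beyond the scatter), brought in the two hydroxy groups together and could not say whether each was needed; the new pair shows that the one at this position can go, and its hydrogen-bond donor with it, since nitro brings none, while the number stays within the scatter. Nothing measured here accounts for this result, so the reason for it remains unknown.

The compounds shown leave open whether the hydroxy group shared by compound 2 and compound 3 would, as the only substituent on that phenyl, hold the number reached in these two compounds. They also leave open how this same aromatic carbon would read with an amine or a carboxylic acid in place of nitro.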